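The source may hold more compounds than are shown below. What is called first, only, known or untested is meant among the compounds shown, and "the series" means these compounds.

Of the compounds shown here, three built on a shared core have been measured in a functional assay on the whole organism (stomach) for inhibition, with Rattus norvegicus as the target; a higher number here means that more compound is needed for the effect, a lower number that less compound is needed. Compound 1 `COc1cc(OC)c(C[S+]([O-])c2ncccc2C(=O)Nc2ccncc2)c(OC)c1` gives 6.8 mg/kg, compound 3 `COc1cc(C)c(C[S+]([O-])c2ncccc2C(=O)Nc2ccncc2)c(OC)c1` gives 5.7 mg/kg, and compound 2 `COc1ccc(C[S+]([O-])c2ncccc2C(=O)Nc2ccncc2)c(OCCF)c1` gives 8.1 mg/kg. Compound 2 thus carries the highest of the three numbers, yet its gap to compound 1 and its gap to compound 3 both lie within the scatter, so no ranking among the three can be read from them. Within the data shown here, the single measured step that changes one place, a 1.2-fold lower number from compound 1 to compound 3 (0.08 log units; within the scatter), also stays within the scatter.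

Compound 4 `CCOc1cc(OC)ccc1C[S+]([O-])c1ncccc1C(=O)Nc1ccncc1` differs from compound 2 in one place: hydrogen in place of fluoro on a saturated chain carbon, two bonds along the chain from an oxygen on an aromatic ring. Among the measured compounds shown here, no measured step touches the 2-fluoroethoxy chain, so nothing among the measured compounds speaks directly to this change; the one available step, a 1.2-fold lower number from compound 1 to compound 3 (0.08 log units; within the scatter), is a different exchange and was itself small. In this assay a step no larger than the scatter is therefore expected, with no firm direction. Compound 4 is expected at 8 mg/kg, with a range from 4 mg/kg to 16 mg/kg. That estimate corresponds to an expected step of a 1.0-fold lower number from compound 2 to compound 4 (0.01 log units; within the scatter).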

Compound 4, dose for half-maximal effect: 19 mg/kg
Compound 4: the middle estimate sits 2.4-fold (0.38 log units) below what was measured; the measured number lies above the stated range.
By their numbers in this assay, from the lowest: compounds 3, 1 and 2 (each within the scatter of the next); then compound 4.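

In this assay, ethoxy in place of 2-fluoroethoxy gives a 2.3-fold higher number from compound 2 to compound 4 (0.37 log units; beyond the scatter), the first step among these compounds to lie beyond the scatter, though only modestly. The earlier compounds shown here left this chain untouched; this pair shows that a single fluoro on a saturated chain carbon, two bonds along the chain from an oxygen on an aromatic ring, is a change the read-out registers, with less compound needed when the fluoro is present. Nothing available explains why this one atom matters.

Going by these compounds, the step has been read on one substitution pattern only, so whether it carries over to the differently substituted rings of compound 1 and compound 3 stays open. Also open, on these data alone, is how a second fluoro on the same carbon, a chloro, a hydroxyl or a longer chain such as propoxy would stand in this assay.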